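This account rests on a few compounds, and the source may have more. Where it says the series, first, only, none or still open, it means among the compounds named here.

The measured compounds and their values:
compound 1, `OC[C@H]1O[C@@H](n2cnc3c(NCc4ccccc4)nccc32)C[C@@H]1O`, in a functional assay on the whole organism (Pleural cavity) with Rattus norvegicus as the target; a higher number here means that more compound is needed for the effect, a lower number that less compound is needed: > 9 mg/kg
compound 2, `Sc1[nH]ccc2ncnc1-2`: 8 mg/kg
compound 3, `OC[C@H]1OC(n2cnc3c(Nc4ccccc4)nccc32)[C@H](O)[C@@H]1O`: > 9 mg/kg

Compound 3 gives only a limit of the assay, not a number: in this assay compound 3 reaches > 9 mg/kg. Compound 1 likewise gives only a limit, > 9 mg/kg. Among the compounds with values here, compound 2 is the one compound here with a measured number, 8 mg/kg. Two of the three values sit at the same limit (the limit of > 9 mg/kg in this assay, at which 2 of the 3 values shown sit), so compound 3 stands at that limit, with no number of its own to set beside compound 2.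

The step to the unmeasured compound 4, `[N-]=[N+]=Nc1nccc2c1ncn2C1O[C@H](CO)[C@@H](O)[C@H]1O`, changes one place: azido in place of anilino on an aromatic carbon. Within the data shown here, no step between two measured compounds is known, so there is no measured guide to how much a change of this kind shifts the dose. The expected step from compound 3 to compound 4, an at least 1.1-fold lower number from compound 3 to compound 4 (0.05 log units; that floor lies within the scatter), is small, toward a lower dose, and may not exceed the scatter. Compound 4 is thus expected to give about 8 mg/kg, within a range from 3 mg/kg to 20 mg/kg, with a fair chance that only a limit is reported again.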

Compound 4, dose for half-maximal effect: > 9 mg/kg
Compound 4: a limit, no number; the forecaster's own chance of this, stated with the estimate: 40%; middle value at least 1.1-fold (0.05 log units) from the limit.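

Compound 4, like compound 3, gives only a limit and not a number, so no step can be read between these two compounds: the limit of > 9 mg/kg in this assay, at which 3 of the 4 values shown sit. The compounds shown leave open whether azido in place of anilino on an aromatic carbon shifts the dose in this assay at all, and by how much.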